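Benzyl ester of a thiophene dihydropyrimidinone: an expected reading

This account rests on a few compounds, and the source may have more. Where it says the series, first, only, none or still open, it means among the compounds named here.

Compound 1 `CC1=C(C(=O)OCc2ccccc2)C(c2ccco2)NC(=O)N1C` and compound 2 `CC1=C(C(=O)OCC(C)C)C(c2cccs2)NC(=O)N1C` share a core and were both tested in an assay on membranes from HeLa cells for displacement of a labelled ligand from adenosine receptor A3 (Homo sapiens), read by scintillation counting, with a stated time of 180 min, tested at 1 uM; a lower number here means less inhibition, a higher number more inhibition at the concentration tested (going by the name of the read-out). Compound 1 gives 11%, and compound 2 gives 5%; the two values lie within the scatter of each other, so no order between them can be read. Among the measured compounds shown here, compound 2 stands at the lowest of the two numbers, with compound 1 the only neighbour, apart from it but not beyond the scatter.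

Compound 3 `CC1=C(C(=O)OCc2ccccc2)C(c2cccs2)NC(=O)N1C` is not yet measured. It differs from compound 2 in a single change: phenyl in place of isopropyl on a saturated chain carbon bound to an oxygen next to a carbonyl group. For the measured compounds named here, no measured pair isolates that change, so there is no step to lean on. The modest value of compound 1, which carries the same benzyl ester, suggests that any step from compound 2 would be small and within the scatter. Compound 3 is therefore expected to show 9%, with a range from 0% to 22%, meaning an estimated step of a number 4 percentage points higher from compound 2 to compound 3 (within the scatter).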

Compound 3, a percentage reported as inhibition, at one concentration (the size of the read-out at that concentration, not a potency): 18%
Estimate against measurement, compound 3: 9 percentage points below; measured number inside the range.
By their numbers in this assay, from the lowest: compounds 2, 1 and 3 (each within the scatter of the next, the first and the last beyond it).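

In this assay the change from isopropyl to phenyl on a saturated chain carbon bound to an oxygen next to a carbonyl group gives a number 13 percentage points higher from compound 2 to compound 3 (beyond the scatter) and so shows that this position can move the reading, if only modestly. The change of thiophen-2-yl in place of furan-2-yl on a saturated ring carbon gives a number 7 percentage points higher from compound 1 to compound 3 (within the scatter) and so sets no order between these two rings. Nothing at hand offers an explanation for either step.

From the compounds shown here alone, what a longer chain, a phenethyl group or a carboxylic acid would read at the ester position remains open. The readings come from a single concentration, so they leave the potency of all three compounds open as well.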